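Coumarin hydrazone series: loss of one nitro group

The source may hold more compounds than are shown below. What is called first, only, known or untested is meant among the compounds shown, and "the series" means these compounds.

Measured so far, in a functional assay, read by spectrophotometry, with a stated time of 5 min; a higher number here means a weaker inhibitor, a lower number a stronger inhibitor:
compound 1 `Nc1ccccc1/N=C\c1cc(=O)oc2cc(OCc3ccccc3)ccc12`, 217000 nM
compound 2 `O=c1cc(/C=N\Nc2ccc([N+](=O)[O-])cc2[N+](=O)[O-])c2c(OCc3ccccc3)cc(OCc3ccccc3)cc2o1`, 292000 nM

Compound 2 holds the top of the two numbers in this assay, but compound 1 stands within the scatter of it, so the two values show no separation that can be read.

The step to compound 3 `O=c1cc(/C=N\Nc2ccc([N+](=O)[O-])cc2)c2c(OCc3ccccc3)cc(OCc3ccccc3)cc2o1` changes one place on the hydrazone aryl ring: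
hydrogen in place of nitro on an aromatic carbon
One nitro group is left in place; the other gives way to a hydrogen.

For the measured compounds named here, no step between measured compounds exists against which this change can be checked. Both measured numbers sit far up the scale in this assay, and nothing in them points to a nitro group as a carrier of inhibition. The expected step of a 1.0-fold higher number from compound 2 to compound 3 (0.01 log units; within the scatter) is therefore none beyond the scatter, with a weakly inhibiting compound 3 as the likely outcome. Compound 3 is estimated at 300000 nM in this assay, within 120000 nM to 750000 nM.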

Compound 3, half-maximal inhibitory concentration: 419000 nM
Estimate against measurement, compound 3: 1.4-fold (0.15 log units) below; measured number inside the range.
By their numbers in this assay, from the lowest: compounds 1, 2 and 3 (each within the scatter of the next).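

For the compounds shown here, this is the first step that can be read across a single change: in this assay, going from 2,4-dinitrophenyl to 4-nitrophenyl gives a 1.4-fold higher number from compound 2 to compound 3 (0.16 log units; within the scatter). At this aromatic carbon, then, nitro and hydrogen cannot be told apart, and removing this nitro group neither gains nor loses readable inhibition. Nothing measured on these compounds accounts for the result, so no cause can be assigned to it.

Going by these compounds, it remains open whether any group on this carbon, such as a carboxylic acid or an amine, would move the number beyond the scatter. Also open, on these data alone, is whether the nitro group that remains in compound 3 matters, a question that a plain phenyl in its place would address.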